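The source may hold more compounds than are shown below. What is called first, only, known or untested is meant among the compounds shown, and "the series" means these compounds.

Working notes on the series. Of the compounds shown here, three sharing one core have been measured in a physicochemical assay for solubility, read by nephelometry, in phosphate buffer, measured as kinetic solubility, at pH 6.5; on this read-out lower numbers stand for lower solubility and higher numbers for higher solubility. Compound 1 `COc1ccc(-c2cc(-c3ccc(S(=O)(=O)N(C)C)cc3)cnc2N)cn1` gives 6.3 ug/mL. Compound 2 `COc1ccc(-c2cc(-c3ccc(C(F)(F)F)cc3)cnc2N)cn1` gives 1.6 ug/mL. Compound 3 `COc1ccc(-c2cc(-c3ccc(C(=O)O)cc3)cnc2N)cn1` gives 6.3 ug/mL, which places compound 3 level with compound 1 at the digits printed, the two together the highest of the three numbers, with compound 2 the furthest away. The measured steps are a 3.9-fold lower number from compound 1 to compound 2 (0.60 log units; beyond the scatter), a 3.9-fold higher number from compound 2 to compound 3 (0.60 log units; beyond the scatter) and no change at the digits printed from compound 1 to compound 3 (within the scatter), so within this set exchanging the group on the aromatic carbon has moved this assay by a modest amount at most, and the exchange between dimethylsulfamoyl and carboxy not at all.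

Compound 4 `COc1ccc(-c2cc(-c3ccc(C(N)=O)cc3)cnc2N)cn1` has not yet been measured. It differs from compound 3 by amino in place of hydroxy on a carbonyl carbon. Among the measured compounds shown here, none of the measured steps is this exchange; the nearest analogy is the step from compound 1 to compound 3, which changed one group on the same aromatic carbon without any change beyond the scatter, and the carbamoyl of compound 4 keeps a hydrogen-bond donor as the carboxy did. The expectation is therefore a step of a 1.3-fold lower number from compound 3 to compound 4 (0.10 log units; within the scatter), not beyond the scatter. Compound 4 is estimated at 5 ug/mL, with a range from 2 ug/mL to 12 ug/mL.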

Compound 4, solubility: 12.5 ug/mL
Compound 4: middle estimate off by 2.5-fold (0.40 log units), on the low side; the whole stated range lies below it.
By their numbers in this assay, from the lowest: compound 2; then compounds 1, 3 and 4 (each within the scatter of the next).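

In this assay the exchange of hydroxy for amino on a carbonyl carbon, which turns carboxy into carbamoyl, is a 2.0-fold higher number from compound 3 to compound 4 (0.30 log units; within the scatter), and the exchange of dimethylsulfamoyl for carbamoyl is a 2.0-fold higher number from compound 1 to compound 4 (0.30 log units; within the scatter), so carbamoyl is a third group on this aromatic carbon that the read-out does not separate from the other two. Among the compounds shown here, the exchange of trifluoromethyl for carbamoyl is a 7.8-fold higher number from compound 2 to compound 4 (0.89 log units; beyond the scatter), which leaves trifluoromethyl as the only one of the four groups that stands apart from the rest, with all of its steps beyond the scatter. Nothing shown here offers an explanation for how these four groups fall on the read-out.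

Still open, going by these compounds, is whether methylamino or dimethylamino in place of amino on this carbonyl carbon would stay with carbamoyl, and whether a nitrile or an aminomethyl on the aromatic carbon would join that group or fall with trifluoromethyl. Also open, on these data alone, is whether the grouping of carbamoyl, carboxy and dimethylsulfamoyl would hold with a group other than the methoxy of the shared core.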